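This account rests on a few compounds, and the source may have more. Where it says the series, first, only, none or still open, it means among the compounds named here.

Measured so far in a functional assay on MCF7 cells (Homo sapiens) for cytotoxicity, read by MTT assay, with a stated time of 48 h; on this read-out lower numbers stand for stronger inhibition and higher numbers for weaker inhibition:
- compound 1 `O=C(CSc1nnc(-c2ccncc2)o1)N/N=C/c1ccc([N+](=O)[O-])cc1`: 31800 nM
- compound 2 `O=C(CSc1nnc(-c2ccncc2)o1)N/N=C/c1ccccc1[N+](=O)[O-]`: 35600 nM

Compound 2 gives the larger of the two numbers, but the gap to it from compound 1, a 1.1-fold higher number from compound 1 to compound 2 (0.05 log units; within the scatter), lies within the scatter, so the two compounds are not distinguished by these data.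

Compound 3 `O=C(CSc1nnc(-c2ccncc2)o1)N/N=C/c1cc(Br)ccc1O` is to be measured in this assay. Relative to compound 2 it changes in one place: 5-bromo-2-hydroxyphenyl in place of 2-nitrophenyl on a carbon with a double bond to nitrogen. Among the compounds with values here, only one measured step exists, a 1.1-fold higher number from compound 1 to compound 2 (0.05 log units; within the scatter), and it concerns 2-nitrophenyl in place of 4-nitrophenyl, not the group entering here; nothing measured bears directly on the present swap. Since both measured numbers sit close together, compound 3 is expected to fall in the same region, with a wide range to cover the untested replacement: estimated 28000 nM, between 8000 nM and 90000 nM. That estimate corresponds to an expected step of a 1.3-fold lower number from compound 2 to compound 3 (0.10 log units; within the scatter).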

Compound 3, half-maximal inhibitory concentration: 7770 nM
Compound 3: the middle estimate sits 3.6-fold (0.56 log units) above what was measured, and the stated range ends above it.
By their numbers in this assay, from the lowest: compound 3; then compounds 1 and 2 (each within the scatter of the next).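

In this assay, the group on a carbon with a double bond to nitrogen now proves able to shift the read-out, which the two nitrophenyl compounds alone did not show. 5-Bromo-2-hydroxyphenyl in place of 2-nitrophenyl gives a 4.6-fold lower number from compound 2 to compound 3 (0.66 log units; beyond the scatter), and in place of 4-nitrophenyl it gives a 4.1-fold lower number from compound 1 to compound 3 (0.61 log units; beyond the scatter), so both steps are modest but lie beyond the scatter. Nothing available explains the size or direction of these steps.

The entering group brings the bromine and the hydroxy group together, so the compounds shown do not separate what each contributes. Also open, on these data alone, is how the series would respond to a phenyl group carrying only a hydroxy group, only a bromine, or instead an amine or a carboxylic acid.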